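Replacing piperidin-1-yl with dimethylamino on the shared core

A few compounds are considered here, and "the series" means these few. Any claim that something is new, unique, unknown or untested is made for them only; others in the source may bear on it.

Measured in an ADME assay on L6 cells (Rattus norvegicus) for cytotoxicity, read by resazurin assay, with a stated time of 72 h; on this read-out lower numbers stand for stronger inhibition and higher numbers for weaker inhibition:
compound 1 `CCOC(=O)CN1CCC2(N3CCCCC3)CC(c3ccc(Cl)cc3)C1C(c1ccc(Cl)cc1)C2`: 13100 nM
compound 2 `O=C(O)CN1CCC2(N3CCCCC3)CC(c3ccc(Cl)cc3)C1C(c1ccc(Cl)cc1)C2`: "not determined" (no result reported)
compound 3 `NCCN1CCC2(N3CCCCC3)CC(c3ccc(Cl)cc3)C1C(c1ccc(Cl)cc1)C2`: 3370 nM

Compound 1 stands at 13100 nM, the higher of the two numbers available, and compound 2 offers no number for comparison. Compound 4 `CCOC(=O)CN1CCC2(N(C)C)CC(c3ccc(Cl)cc3)C1C(c1ccc(Cl)cc1)C2` has not yet been measured. It carries dimethylamino in place of piperidin-1-yl on a saturated ring carbon of the core of compound 1: dimethylamino in place of piperidin-1-yl on a saturated ring carbon. Among the compounds with values here, no measured step covers this change. Within the data shown here, the only step available is a 3.9-fold lower number from compound 1 to compound 3 (0.59 log units; beyond the scatter), a modest one made on a saturated chain carbon bound to an amine nitrogen in a ring, not on the saturated ring carbon that changes here. It shows only how far the number has moved within this small set, and it gives no direction for compound 4. In this assay, no step beyond the scatter is therefore expected, and the expected step is a 1.2-fold higher number from compound 1 to compound 4 (0.09 log units; within the scatter). For compound 4 the estimated value is 16000 nM, with an expected range from 6000 nM to 40000 nM.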

Compound 4, half-maximal inhibitory concentration: 5120 nM
Beside the measured number, compound 4's estimate is 3.1-fold (0.49 log units) above it, outside the stated range (below it).
By their numbers in this assay, from the lowest: compounds 3 and 4 (each within the scatter of the next); then compound 1.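

In this assay, dimethylamino in place of piperidin-1-yl on the saturated ring carbon gives a 2.6-fold lower number from compound 1 to compound 4 (0.41 log units; beyond the scatter), showing that this position, which the earlier step did not touch, also affects the number. Here, dimethylamino, with 3 heavy atoms and no ring, replaces piperidin-1-yl, with 6 heavy atoms and one six-membered non-aromatic ring, while the hydrogen-bond donor and acceptor counts and the net charge stay the same. Nothing available explains why the number moved with this change.

The compounds shown leave open whether the number follows the size of the group at this carbon, which pyrrolidin-1-yl or diethylamino there could help to test. They also leave open whether the same change would give a similar step on the core of compound 3, with its primary amine chain.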